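Benzofuran in place of furan on the shared core

The compounds below may be only part of what the source reports. "The series", "measured", "known", "first", "only" and "open" are said of these compounds alone.

Of the compounds shown here, two so far have a reading in an ADME assay on BJ cells (Homo sapiens), read by MTT assay, with a stated time of 72 h; on this read-out higher numbers stand for weaker inhibition and lower numbers for stronger inhibition. Compound 1 (`CNc1ncnc2c1c(-c1ccsc1)cn2[C@@H]1O[C@H](CO)[C@@H](O)[C@H]1O`) reads > 100000 nM, which is a limit of the assay and not a number. This places it at the limit of > 100000 nM in this assay, at which 1 of the 2 values shown sits. Among the measured compounds shown here, compound 2 (`Nc1nc2c(c(-c3ccoc3)cn2[C@@H]2O[C@H](CO)[C@@H](O)[C@H]2O)c(=O)[nH]1`) gives 21500 nM, the only true number available, so it is the sole numerical anchor for the series. For the measured compounds named here, the two compounds differ in more than one place, and their values offer no measured step to carry forward.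

Compound 3 (`Nc1nc2c(c(-c3cc4ccccc4o3)cn2[C@@H]2O[C@H](CO)[C@@H](O)[C@H]2O)c(=O)[nH]1`) has 1-benzofuran-2-yl in place of furan-3-yl on an aromatic carbon of the five-membered aromatic ring with 1 nitrogen, and the count runs as follows: 1-benzofuran-2-yl in place of furan-3-yl on an aromatic carbon.

Going by the values given here, with no measured step as a guide, no clear direction is expected in this assay. The expected change, a 1.1-fold lower number from compound 2 to compound 3 (0.03 log units; within the scatter), stays within the usual scatter, although a single number leaves the uncertainty wide. For compound 3 the estimated value is 20000 nM, with an expected range of 4000 nM to 100000 nM.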

Compound 3, half-maximal inhibitory concentration: > 100000 nM
Compound 3 ended at the assay's limit; the forecaster's own chance of this, stated with the estimate: 25%; at least 5.0-fold (0.69 log units) between middle value and limit.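

In this assay, this aromatic carbon now has its first measured step, an at least 4.6-fold higher number from compound 2 to compound 3 (0.66 log units; beyond the scatter), which shows that the reading responds to the group carried at this position. Compound 3 gives > 100000 nM, which is a limit of the assay and not a number, so the step has a lower bound and no upper one. The entering 1-benzofuran-2-yl adds a six-membered aromatic ring of carbon only and keeps the same counted hydrogen-bond donors and acceptors as furan-3-yl, and with this change the series has one true number left, as most readings now sit at the ceiling: the limit of > 100000 nM in this assay, at which 2 of the 3 values shown sit.

Among the compounds shown here, the single step changes both the ring system and the point of attachment, so it leaves open which of the two goes with the higher number, a question on which furan-2-yl at this place would bear directly. Also open, going by these compounds, is whether any group at this position gives a lower number than compound 2 gives, for instance a small aminomethyl group or a carboxylic acid on the same core.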